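The source may hold more compounds than are shown below. What is called first, only, known or untested is meant among the compounds shown, and "the series" means these compounds.

Measured in a functional assay on A549 cells (Homo sapiens) for cytotoxicity, read by colorimetric assay and MTT assay; a lower number here means a stronger inhibitor, a higher number a weaker inhibitor:
- Compound 1 `COc1ccc2cc(-c3ccccc3)c(O)nc2c1`: 10000 nM
- Compound 2 `COc1ccc(-c2cc3cccc(OC)c3nc2O)cc1`: 10000 nM
- Compound 3 `CCN(CC)C(=O)Cn1c(=O)c(-c2ccc(OC)cc2)cc2c(OC)cc(OC)cc21`: 10000 nM

Compound 3 gives 10000 nM, the same reading as compound 1 and compound 2 at the digits shown. The three compounds therefore cannot be ranked in this assay.

Compound 4 `COc1ccc(-c2cc3c(OC)cc(OC)cc3n(CCCC#N)c2=O)cc1` has not yet been measured. It is built like compound 3 except for one change on a saturated chain carbon bound to an aromatic nitrogen, where 2-cyanoethyl stands in place of diethylcarbamoyl: 2-cyanoethyl in place of diethylcarbamoyl on a saturated chain carbon bound to an aromatic nitrogen. Cut one bond further out, the same difference reads (diethylcarbamoyl)methyl to 3-cyanopropyl.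

For the measured compounds named here, no measured pair differs in only one place, so the data offer no direct guide to this change. The only anchor is the shared reading of the three measured compounds, so no shift beyond the scatter is expected in either direction. The expected step, no change at the digits printed from compound 3 to compound 4 (within the scatter), is correspondingly small, although a stronger result remains possible. For compound 4 the estimate is 10000 nM, with an expected range from 3000 nM to 12000 nM.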

Compound 4, half-maximal inhibitory concentration: 10000 nM
For compound 4 middle estimate and measured number coincide at the digits printed, within the range that was stated.
By their numbers in this assay, from the lowest: compounds 1, 2, 3 and 4 (each within the scatter of the next).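

Putting 2-cyanoethyl in place of diethylcarbamoyl on a saturated chain carbon bound to an aromatic nitrogen gives no change at the digits printed from compound 3 to compound 4 (within the scatter) in this assay. This is the only pair shown that differs in one place, so it gives the first direct reading at this position. Going from a group of seven heavy atoms with a double bond to one of four heavy atoms with a triple bond does not separate the two compounds in this assay. Nothing measured here bears on why the two readings match.

All four compounds share one reading, so the compounds shown do not reveal whether any group in this place can shift it in either direction. An amine, a carboxylic acid or a longer chain in this place remains an open test.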